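Aryl swap on the sulfonamide nitrogen: compound 3

The source may hold more compounds than are shown below. What is called first, only, known or untested is meant among the compounds shown, and "the series" means these compounds.

Among the compounds with values here, compound 1 `O=S(=O)(Nc1ccc(Cl)cc1Cl)c1ccc(-c2cnc(C3CC3)o2)cc1` gives 74500 nM in a functional assay on cells (leukaemia cell line, Homo sapiens) for inhibition, read by sulforhodamine B assay, with a stated time of 48 h (on this read-out higher numbers stand for weaker inhibition of growth and lower numbers for stronger inhibition of growth), the highest of the two numbers measured so far; its nearest neighbour is compound 2 `Cc1ccc(Cl)c(NS(=O)(=O)c2ccc(-c3cnc(C4CC4)o3)cc2)c1`, which gives 52800 nM. Within the data shown here, the step of a 1.4-fold lower number from compound 1 to compound 2 (0.15 log units; within the scatter) is the only one that changes the same place, the aryl on the sulfonamide nitrogen, and it stays within the scatter. Compound 3 `O=S(=O)(Nc1ccc(I)c(Cl)c1)c1ccc(-c2cnc(C3CC3)o2)cc1` has not been measured. It differs from compound 1 as follows: 3-chloro-4-iodophenyl in place of 2,4-dichlorophenyl on a sulfonamide nitrogen. Among the measured compounds shown here, nothing in the two measured compounds separates the contribution of either halogen pattern from the shared core, and the one measured change at this position did not move the number beyond the scatter, so no step beyond the scatter is expected in either direction. Compound 3 is estimated at 60000 nM, with a range of 25000 nM to 150000 nM; the expected step is a 1.2-fold lower number from compound 1 to compound 3 (0.09 log units; within the scatter).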

Compound 3, concentration for total growth inhibition: 19600 nM
The estimate for compound 3 lay 3.1-fold (0.49 log units) above the measured number; the whole stated range lies above it.
By their numbers in this assay, from the lowest: compound 3; then compounds 2 and 1 (each within the scatter of the next).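

In this assay, the aryl on the sulfonamide nitrogen now proves able to move the number beyond the scatter: 3-chloro-4-iodophenyl gives a 3.8-fold lower number from compound 1 to compound 3 (0.58 log units; beyond the scatter) and a 2.7-fold lower number from compound 2 to compound 3 (0.43 log units; beyond the scatter), whereas the earlier swap gave only a 1.4-fold lower number from compound 1 to compound 2 (0.15 log units; within the scatter). The groups leaving and entering have the same heavy-atom count and no hydrogen-bond donors or acceptors, so these counts do not distinguish them, while the halogen content and substitution pattern do differ. No available measurement explains the shift.

Compound 3 introduces iodine and a different chlorine pattern together, so the share of the step belonging to each remains unresolved. Also open, as far as these compounds go, is how this series would respond to an amine or a carboxylic acid on the phenyl ring in place of the halogens.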